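The source may report more compounds than this note shows. Statements on the series, on what has been measured and on what is new or still open speak of the compounds shown alone.

Working notes on the series. Compound 3 `NCCCNCCCCNCCCNC(=O)[C@H](CC1CCCCC1)NC(=O)CC1CC2CCC1C2` gives 25.6 nM in an assay on cells for antagonist activity at Neuronal acetylcholine receptor; alpha4/beta2 (Homo sapiens), read by two-electrode voltage clamp, with a stated time of 1 min (a higher number here means a weaker inhibitor, a lower number a stronger inhibitor), the second highest of the three numbers; compound 1 `NCCCNCCCCNCCCNC(=O)[C@H](CC1CCCCC1)NC(=O)C1CCC1` gives 20.8 nM and compound 2 `NCCCNCCCCNCCCNC(=O)[C@H](CC1CCCCC1)NC(=O)C1CCCCC1` gives 31.4 nM, both within the scatter of compound 3. Compound 4 `NCCCNCCCCNCCCNC(=O)[C@H](CC1CCCCC1)NC(=O)c1ccc(-c2ccccc2)cc1` carries the change (a group of 12 heavy atoms (12 carbon; 2 six-membered aromatic rings of carbon only) in place of a group of 8 heavy atoms (8 carbon; 2 five-membered non-aromatic rings of carbon only), on a carbonyl carbon). The steps at the same carbonyl carbon bear on it: a 1.2-fold higher number from compound 1 to compound 3 (0.09 log units; within the scatter), a 1.2-fold lower number from compound 2 to compound 3 (0.09 log units; within the scatter) and a 1.5-fold higher number from compound 1 to compound 2 (0.18 log units; within the scatter), all within the scatter. The entering group is aromatic and larger than any tried so far, so the measured steps cover it only loosely, but none of them moved the number beyond the scatter. A step of a 1.2-fold higher number from compound 3 to compound 4 (0.07 log units; within the scatter) is therefore expected, none beyond the scatter. For compound 4 the estimate is 30 nM, within 12 nM to 80 nM.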

Compound 4, half-maximal inhibitory concentration: 25.8 nM
The estimate for compound 4 lay 1.2-fold (0.07 log units) above the measured number; the measured number falls inside the stated range.
By their numbers in this assay, from the lowest: compounds 1, 3, 4 and 2 (each within the scatter of the next).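

At this carbonyl carbon, the aromatic 4-phenylphenyl group does not separate from the non-aromatic carbon rings in this assay (one step is a 1.0-fold higher number from compound 3 to compound 4 (0.00 log units; within the scatter); the others are a 1.2-fold lower number from compound 2 to compound 4 (0.09 log units; within the scatter) and a 1.2-fold higher number from compound 1 to compound 4 (0.09 log units; within the scatter)). The absence of any step beyond the scatter therefore now spans both non-aromatic and aromatic carbon-only groups, and no compound shown goes against this. Nothing available explains this flat result. Still open, from the compounds shown here alone, is whether a group carrying an amine or a carboxylic acid at this place would give a step beyond the scatter. The compounds shown also leave open how changes elsewhere on the shared core would read.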